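This account rests on a few compounds, and the source may have more. Where it says the series, first, only, none or still open, it means among the compounds named here.

The shared core carries a sulfonamide-linked uracil-like unit on a benzene ring that also bears a triazole with an aryl group. Compound 1 `Cc1ccc(-n2cc(-c3ccccc3NS(=O)(=O)c3c[nH]c(=O)[nH]c3=O)nn2)cc1` has a 4-methylphenyl on that triazole, and in an ADME assay on GES1 cells (Homo sapiens) for cytotoxicity, read by MTT assay, with a stated time of 24 h (on this read-out higher numbers stand for lower toxicity in this test and lower numbers for higher toxicity in this test), compound 1 gives 32400 nM. Compound 2 `O=c1[nH]cc(S(=O)(=O)Nc2ccccc2-c2cn(-c3cccc(F)c3)nn2)c(=O)[nH]1` replaces the methyl with a fluorine on the phenyl, and in this assay compound 2 is recorded as "not toxic" (no number reported), which is a description rather than a number, so compound 2 cannot be placed on the numeric scale next to compound 1; all that can be said is that it showed no measurable toxicity in the test.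

Compound 3 `O=c1[nH]cc(S(=O)(=O)Nc2ccccc2-c2cn(-c3cccc(Cl)c3)nn2)c(=O)[nH]1` differs from compound 2 only in that a chloro replaces a fluoro on an aromatic carbon, (chloro in place of fluoro on an aromatic carbon), that is, 3-fluorophenyl becomes 3-chlorophenyl. Among the compounds with values here, no measured pair shows what such a swap does in this assay, so the expectation rests on the two compounds above, both of which sit at high concentrations or beyond. A step within the usual scatter, in no particular direction, is expected. Compound 3 is therefore estimated at 40000 nM in this assay, with a plausible range from 15000 nM to 100000 nM.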

Compound 3, half-maximal cytotoxic concentration: > 100000 nM
Compound 3 was reported as a limit (the forecaster's own chance of this, stated with the estimate: 50%); middle value at least 2.5-fold (0.39 log units) from the limit.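

In this assay, compound 3 gives > 100000 nM, which is a limit of the assay and not a number. Within the data shown here, this gives the first readable comparison of the aryl groups on the triazole: with 3-chlorophenyl in place of 4-methylphenyl, the record shows an at least 3.0-fold higher number from compound 1 to compound 3 (0.48 log units; beyond the scatter), which on this read-out means lower toxicity in this test, so the group at this position can change the result. The printed step is only a minimum, and its true size remains unknown, because it rests on a limit: the limit of > 100000 nM in this assay, at which 1 of the 3 values shown sits.

Compound 2 has only a description, so the step from it to compound 3 cannot be read, and these compounds do not show how chloro and fluoro compare at this place. From the compounds shown here alone, compound 1 and compound 3 differ in both the group and where it sits on the phenyl ring, so it remains open whether the change of group, its place or both lie behind the step, and how a 3-methylphenyl, a 4-chlorophenyl or a phenyl carrying an amine would read in this test.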